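Methoxy removal from compound 3

This account rests on a few compounds, and the source may have more. Where it says the series, first, only, none or still open, it means among the compounds named here.

Every measured compound in a toxicity assay on THP-1 cells (Homo sapiens) for inhibition (on this read-out lower numbers stand for higher toxicity in this test and higher numbers for lower toxicity in this test), sits at a limit. Compound 1 `Cn1c(-c2ccccc2)cnc1NC(=O)c1ccc(Cl)cc1` gives > 100000 nM, a limit. Compound 2 `Cc1ccc(C(=O)Nc2ncc(-c3ccccc3)n2C)cc1` gives > 50000 nM, also a limit. Compound 3 `COc1ccc(-c2cnc(NC(=O)c3cccc(Cl)c3)n2C)cc1` gives > 28000 nM, again a limit, so its standing is open-ended. Compound 4 `Cn1c(-c2ccccc2)cnc1NC(=O)c1cccc(Cl)c1` differs from it by hydrogen in place of methoxy on an aromatic carbon, with 4-methoxyphenyl becoming phenyl. Within the data shown here, the only step between measured compounds, a step that the two limits leave unreadable from compound 1 to compound 2, has no readable size, and it does not touch this position. No fall in the read-out is expected, and another limit is likely. The expected step is a step that the limit leaves unreadable from compound 3 to compound 4. Compound 4 is estimated at 60000 nM, with an expected range of 28000 nM to 100000 nM.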

Compound 4, half-maximal cytotoxic concentration: > 50000 nM
Compound 4: a limit, no number (the forecaster's own chance of this, stated with the estimate: 85%); the middle value does not contradict the limit.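

Compound 4 sits at a limit in this assay, as do compound 1, compound 2 and compound 3, and its steps to these three cannot be read. The compounds shown leave open at what concentration any of them becomes toxic in this test.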